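Estimating Compound 4 from Three Measured Relatives

A few compounds are considered here, and "the series" means these few. Any claim that something is new, unique, unknown or untested is made for them only; others in the source may bear on it.

Compound 1 `COc1ccc(/C=C/C(=O)c2cccc(N=[N+]=[N-])c2)cc1O` gives 1960 nM in a functional assay on RAW264.7 cells (Mus musculus) for inhibition, with a stated time of 4 days; on this read-out higher numbers stand for weaker inhibition and lower numbers for stronger inhibition.
Compound 2 `C=C(C)c1cn(-c2cccc(C(=O)/C=C/c3ccc(O)c(OC)c3)c2)nn1` gives 9790 nM in this assay.
Compound 3 `COc1cc(/C=C/C(=O)c2cccc(-n3cc(-c4ccccc4)nn3)c2)ccc1O` gives 16800 nM in this assay.

Among these three numbers compound 2 stands second highest; compound 3 is its nearest neighbour, while compound 1 lies furthest away with a markedly lower number. The unmeasured compound 4 `COc1ccc(-c2cn(-c3cccc(C(=O)/C=C/c4ccc(O)c(OC)c4)c3)nn2)cc1` differs from compound 2 by 4-methoxyphenyl in place of 1-methylethenyl on an aromatic carbon. For the measured compounds named here, the one measured step that bears on this change is a 1.7-fold higher number from compound 2 to compound 3 (0.23 log units; within the scatter), where a phenyl entered on the same aromatic carbon and the number hardly moved. Since compound 4 carries a 4-methoxyphenyl there instead, a similarly small shift toward a higher number, or none beyond the scatter, is expected. Compound 4 is therefore estimated at 15000 nM, between 6000 nM and 40000 nM, meaning an expected step of a 1.5-fold higher number from compound 2 to compound 4 (0.19 log units; within the scatter).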

Compound 4, half-maximal inhibitory concentration: 7900 nM
Compound 4: middle estimate off by 1.9-fold (0.28 log units), on the high side; the measured number falls inside the stated range.
By their numbers in this assay, from the lowest: compound 1; then compounds 4, 2 and 3 (each within the scatter of the next, the first and the last beyond it).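

Putting 4-methoxyphenyl in place of 1-methylethenyl gives a 1.2-fold lower number from compound 2 to compound 4 (0.09 log units; within the scatter), so in this assay this aromatic carbon accepts the larger group without a shift beyond the scatter. The methoxy adds something the plain phenyl did not show: methoxy in place of hydrogen gives a 2.1-fold lower number from compound 3 to compound 4 (0.33 log units; beyond the scatter), a modest step, but one beyond the scatter. No measurement here offers an explanation for either step. From the compounds shown here alone, whether an amine or a carboxylic acid in place of that methoxy would move the number the same way stays open, as does the effect of a longer chain on this aromatic carbon.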